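Pyrazoline amide series: oxolanyl to pyridinyl at the carbonyl

The source may hold more compounds than are shown below. What is called first, only, known or untested is meant among the compounds shown, and "the series" means these compounds.

The series shares a pyrazoline core carrying a phenyl group and an acyl group on the ring nitrogen. Compound 1 `O=C(C1CCOC1)N1N=CCC1c1ccccc1` carries an oxolan-3-yl group on the carbonyl carbon; in a physicochemical assay for lipophilicity, read by HPLC, measured as chromatographic lipophilicity, at pH 7.4 (on this read-out lower numbers stand for lower lipophilicity and higher numbers for higher lipophilicity), compound 1 gives 3. Compound 2 `O=C(C1CCN(C(=O)C(F)(F)F)CC1)N1N=CCC1c1ccccc1` carries instead a piperidin-4-yl group bearing a trifluoroacetyl group; in this assay compound 2 gives 4.9. Compound 1 thus stands at the lower of the two numbers measured, with compound 2 lying higher by a margin beyond the usual scatter. Among the measured compounds shown here, no single-point step between measured compounds is available for this pair.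

Compound 3 `O=C(c1ccccn1)N1N=CCC1c1ccccc1` is not yet measured. Relative to compound 1 the change is pyridin-2-yl in place of oxolan-3-yl on a carbonyl carbon. The amide-type nitrogen in the ring, the carbonyl and the rest of the core are unchanged.

Given that compound 1 gives 3 and that the change swaps a five-membered non-aromatic ring for a six-membered aromatic ring of one more heavy atom, a modest upward step is expected in this assay, not a large one; the expected step is a number 0.50 log units higher from compound 1 to compound 3 (beyond the scatter). Compound 3 is accordingly estimated at 3.5, within a range of 2.9 to 4.1.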

Compound 3, distribution coefficient: 2.4
For compound 3 the middle estimate is 1.10 log units above the measured one; measured number outside the range, below it.
By their numbers in this assay, from the lowest: compound 3; then compound 1; then compound 2.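

Among the compounds shown here, the step on the carbonyl carbon is the first single-change comparison: pyridin-2-yl in place of oxolan-3-yl gives a number 0.60 log units lower from compound 1 to compound 3 (beyond the scatter) in this assay, so at this place a six-membered aromatic ring with one more heavy atom does not bring a higher number. The two groups have the same hydrogen-bond donor and acceptor counts and neither carries a net charge, so those counts do not separate them, whereas ring size, aromatic character and the identity of the hetero atom all change together in this one step. No measurement available here accounts for the direction of the step.

With these three features changed at once, the compounds shown do not tell how much of the step goes with the aromatic ring and how much with its nitrogen, a question that a phenyl or a cyclopentyl group on the same carbonyl carbon would address. Also open, as far as these compounds go, is whether the step would hold with an amine or a carboxylic acid carried on the pyridin-2-yl ring.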